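Moving the trifluoromethyl group on the aryl ether

The source may report more compounds than this note shows. Statements on the series, on what has been measured and on what is new or still open speak of the compounds shown alone.

Measured in a functional assay on CRL2813 cells (Homo sapiens) for antiproliferative activity, read by sulforhodamine B assay, with a stated time of 3 days, in the presence of a further agent that is not named here; on this read-out lower numbers stand for stronger inhibition and higher numbers for weaker inhibition:
- compound 1 `O=C(Nc1cccc(C(F)(F)F)c1)N[C@H]1CC[C@H](Oc2cccc(C(F)(F)F)c2)CC1`: 4900 nM
- compound 2 `O=C(Nc1cccc(C(F)(F)F)c1)N[C@H]1CC[C@@H](Oc2ccc(F)cc2)CC1`: 10400 nM

Compound 1 holds the lower of the two numbers, and the gap up to compound 2 lies beyond the usual scatter. The next compound is compound 3 `O=C(Nc1cccc(C(F)(F)F)c1)N[C@H]1CC[C@H](Oc2ccc(C(F)(F)F)cc2)CC1`, which differs from compound 1 by one change: 4-(trifluoromethyl)phenyl in place of 3-(trifluoromethyl)phenyl on an oxygen on a saturated carbon. It places 4-(trifluoromethyl)phenyl where 3-(trifluoromethyl)phenyl stood on the oxygen. Within the data shown here, no measured pair shows a change of this kind, so no step beyond the scatter is expected in this assay. The expected result is a 1.2-fold higher number from compound 1 to compound 3 (0.09 log units; within the scatter). Compound 3 is estimated at 6000 nM, with an expected range of 2500 nM to 14000 nM.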

Compound 3, half-maximal inhibitory concentration: 5000 nM
Compound 3: middle estimate off by 1.2-fold (0.08 log units), on the high side; the range from low to high includes it.
By their numbers in this assay, from the lowest: compounds 1 and 3 (each within the scatter of the next); then compound 2.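

In this assay, exchanging 3-(trifluoromethyl)phenyl for 4-(trifluoromethyl)phenyl gives a 1.0-fold higher number from compound 1 to compound 3 (0.01 log units; within the scatter), so this pair separates the two placements of the trifluoromethyl group by no measurable amount. On an oxygen on a saturated carbon, either aryl group is accepted equally within the scatter. Nothing measured here accounts for this result.

Going by these compounds, whether a carboxylic acid or an amine on this phenyl ring would be accepted remains open. Compound 2 differs from compound 1 and compound 3 in more than one place, so it does not show what its aryl group alone contributes.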